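The source may hold more compounds than are shown below. What is called first, only, known or untested is meant among the compounds shown, and "the series" means these compounds.

Three compounds have been measured in a functional assay (Homo sapiens) for inhibition; on this read-out lower numbers stand for stronger inhibition and higher numbers for weaker inhibition:

compound 1, `CCCCOc1cccc(C(=O)/C=C/c2ccc(OC)cc2OC)c1`, gives 65000 nM
compound 2, `COc1ccc(/C=C/C(=O)c2cccc([N+](=O)[O-])c2)c(OC)c1`, gives 18000 nM
compound 3, `CCCCOc1ccccc1/C=C/C(=O)c1ccc(OC)c(OC)c1OC`, gives 52000 nM

Compounds 1 and 2 differ in one place: nitro in place of butoxy on an aromatic carbon. This change gave a 3.6-fold lower number from compound 1 to compound 2 (0.56 log units; beyond the scatter). Compound 3 shares with compound 1 the butoxy group and the three methoxy groups, but the difference between the two cores is not broken down here; in this assay compound 3 and compound 1 sit within the usual scatter of each other.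

Compound 4, `COc1ccc(C(=O)/C=C/c2ccccc2[N+](=O)[O-])c(OC)c1OC`, has not yet been measured. It differs from compound 3 by nitro in place of butoxy on an aromatic carbon. Going by the values given here, this is the same kind of change as the one from compound 1 to compound 2, but the place is not identical: there the nitro sits meta to a large group, here it sits ortho to a large group. Because a 3.6-fold lower number from compound 1 to compound 2 (0.56 log units; beyond the scatter) was seen once in this set, a step of similar size is expected here, though with wider uncertainty given the different place. The expected step is a 2.9-fold lower number from compound 3 to compound 4 (0.46 log units; beyond the scatter). Compound 4 is estimated at 18000 nM in this assay, with a likely range from 6000 nM to 50000 nM.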

Compound 4, half-maximal inhibitory concentration: 7000 nM
For compound 4 the middle estimate is 2.6-fold (0.41 log units) above the measured one; low and high end bracket the measured number.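

In this assay, putting nitro in place of butoxy on an aromatic carbon gave a 7.4-fold lower number from compound 3 to compound 4 (0.87 log units; beyond the scatter). Set beside the earlier case, the change lowers the number on both cores, and the two step sizes cannot be told apart: the same change on two cores in this assay, a 3.6-fold lower number (0.56 log units; beyond the scatter) from compound 1 to compound 2 and a 7.4-fold lower number (0.87 log units; beyond the scatter) from compound 3 to compound 4, 2.1-fold (0.31 log units) apart, within the scatter of two such steps This suggests that the change carries over between these two cores, but it rests on only two pairs and does not show that it would hold on any other core, nor does it explain why the number falls.

The compounds shown leave open whether the lower number comes from the arrival of nitro or simply from the loss of butoxy, and a shorter chain such as ethoxy or a bare hydrogen in the same place could help separate the two. Going by these compounds, it also remains open whether a nitrile, an amine or a carboxylic acid in that place would give a step of similar size.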